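The source may hold more compounds than are shown below. What is called first, only, known or untested is meant among the compounds shown, and "the series" means these compounds.

Measured so far in a functional assay on SW1573 cells (Homo sapiens) for inhibition, read by sulforhodamine B assay, with a stated time of 48 h; on this read-out lower numbers stand for stronger inhibition of growth and higher numbers for weaker inhibition of growth:
compound 1 `COC(=O)[C@@]1(C)CCC=C2[C@@H]1CC[C@@H](C)[C@]2(C)Cc1c(C)[nH]c2ccccc12`: 14000 nM
compound 2 `COC(=O)[C@@]1(C)CCC=C2[C@@H]1CC[C@@H](C)[C@]2(C)Cc1c(C)[nH]c2ccc(Br)cc12`: 14000 nM
compound 3 `COC(=O)[C@@]1(C)CC[C@@H]2C3=C1CC[C@@H](C)[C@]3(C)C[C@@H]1c3ccccc3N[C@H]21`: 30000 nM

In this assay compound 3 gives the highest of the three numbers; its gap to compound 1 and its gap to compound 2 both lie beyond the scatter, while compound 1 and compound 2 give the same number within the scatter. Compound 4 `COC(=O)[C@@]1(C)CC[C@@H]2C3=C1CC[C@@H](C)[C@]3(C)C[C@@H]1c3cc(Br)ccc3N[C@H]21` is not yet measured. It differs from compound 3 in one place: bromo in place of hydrogen on an aromatic carbon. Within the data shown here, the one measured step of the same kind is no change at the digits printed from compound 1 to compound 2 (within the scatter), made on the core of compound 1 rather than on the core of compound 3. Among the measured compounds shown here, no other step bears on the change. On that single precedent, no step beyond the scatter is expected in this assay in either direction. Compound 4 is therefore expected at 30000 nM, with a range from 14000 nM to 65000 nM. The expected step is no change at the digits printed from compound 3 to compound 4 (within the scatter). For the measured compounds named here, the width of the range reflects that the only precedent sits on a different core.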

Compound 4, concentration for 50% growth inhibition: 45000 nM
For compound 4 the middle estimate is 1.5-fold (0.18 log units) below the measured one; the measured number falls inside the stated range.
By their numbers in this assay, from the lowest: compounds 1 and 2 (each within the scatter of the next); then compounds 3 and 4 (each within the scatter of the next).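

In this assay, bromo in place of hydrogen on an aromatic carbon now has a reading on a second core, where the step is a 1.5-fold higher number from compound 3 to compound 4 (0.18 log units; within the scatter). On the core of compound 3, then, this exchange at the place meta to a fused ring and para to a fused ring does not carry the number beyond the scatter. The exchange reads alike on the two cores shown: the same change on two cores in this assay, no change at the digits printed (within the scatter) from compound 1 to compound 2 and a 1.5-fold higher number (0.18 log units; within the scatter) from compound 3 to compound 4, 1.5-fold (0.18 log units) apart, within the scatter of two such steps

On these data alone, all four compounds carry only hydrogen or bromo on this aromatic carbon, so it remains open whether a smaller halogen such as fluoro, a methoxy, an amine or a carboxylic acid there would give a step beyond the scatter. The other aromatic carbons of the same ring also remain unread for any substituent.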